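A few compounds are considered here, and "the series" means these few. Any claim that something is new, unique, unknown or untested is made for them only; others in the source may bear on it.

Measured compounds:
compound 1 `COc1ccc(S(=O)(=O)NC2=NCCN2C(=S)SN2CCn3c2nsc3=S)cc1`: >= 20000 nM
compound 2 `O=S(=O)(NC1=NCCN1C(=S)SN1CCn2c1nsc2=S)c1cccc(Cl)c1`: >= 20000 nM

In a functional assay on KYSE-510 cells (Homo sapiens) for antiproliferative activity, read by crystal violet staining, with a stated time of 96 h (a higher number here means a weaker inhibitor of growth, a lower number a stronger inhibitor of growth), compound 1 gives >= 20000 nM, which is a limit of the assay and not a number. Compound 2 likewise gives >= 20000 nM in this assay, again a limit. Among the compounds with values here, both measured compounds share one core and differ only in the aryl group on the sulfonyl sulfur, so the one measured step, a step that the two limits leave unreadable from compound 1 to compound 2, cannot be read in size; this rests on (the limit of >= 20000 nM in this assay, at which 2 of the 2 values shown sit). Compound 1 therefore stands only at that limit, with no number of its own.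

Compound 3 `O=S(=O)(NC1=NCCN1C(=S)SN1CCn2c1nsc2=S)c1cccc2ccccc12` differs from compound 1 by naphthalen-1-yl in place of 4-methoxyphenyl on a sulfonyl sulfur. Within the data shown here, no measured step covers this change, and the only measured step gives no readable size, so there is no ground to expect a shift beyond the scatter in either direction. Compound 3 is therefore expected to stay at the limit, with an estimated value of 20000 nM and a range from 6000 nM to 40000 nM. The estimated step of a number no higher from compound 1 to compound 3 (the limit leaves the size open) is expected to be essentially none.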

Compound 3, concentration for 50% growth inhibition: >= 20000 nM
Compound 3 gave a limit, no number; the forecaster's own chance of this, stated with the estimate: 75%; the middle value lies on the limit itself.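

Compound 3, like compound 1 and compound 2, gives a limit of the assay and not a number, so no step among these three compounds can be read in size. What the compounds shown leave open is whether any aryl group on the sulfonyl sulfur of the shared core can bring a measurable value in this assay at all.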